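The source may report more compounds than this note shows. Statements on the series, on what has been measured and on what is new or still open speak of the compounds shown alone.

Measured so far in a functional assay on HeLa cells (Homo sapiens) for antiproliferative activity, with a stated time of 5 days; on this read-out lower numbers stand for stronger inhibition and higher numbers for weaker inhibition:

compound 1 `COc1ccc(-n2nc(-c3ccc4ccccc4c3)nc2N2C(=O)C(C)OC23C=CC(=O)C=C3)cc1` gives 140 nM
compound 2 `O=C1C=CC2(C=C1)OCC(=O)N2c1nc(-c2ccc3c(c2)OCCO3)nn1-c1ccccc1` gives 70 nM
compound 3 `O=C1C=CC2(C=C1)OCC(=O)N2c1nc(-c2ccc3ccccc3c2)nn1-c1ccc2ccccc2c1` gives 210 nM

The numbers for compound 2 (70 nM) and compound 1 (140 nM) lie within the usual scatter of each other, so these two cannot be told apart. Compound 3 (210 nM) has a higher number than compound 2, beyond the scatter, which means weaker inhibition.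

Compound 4 (`O=C1C=CC2(C=C1)OCC(=O)N2c1nc(-c2cccc3ccccc23)nn1-c1ccccc1`) has not been measured yet. It differs from compound 2 in one place, an aromatic carbon of a five-membered aromatic ring with 3 nitrogen, where naphthalen-1-yl stands in place of 2,3-dihydro-1,4-benzodioxin-6-yl (naphthalen-1-yl in place of 2,3-dihydro-1,4-benzodioxin-6-yl on an aromatic carbon). Within the data shown here, no measured pair shows this change alone, so the evidence is indirect. Compound 1 (140 nM) and compound 3 (210 nM) also carry an all-carbon aromatic group on that carbon, though both differ elsewhere too. In this assay the expected change is a 2.1-fold higher number from compound 2 to compound 4 (0.33 log units; beyond the scatter) toward weaker inhibition. For compound 4 the estimated value is 150 nM (expected range 60 nM to 400 nM).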

Compound 4, half-maximal inhibitory concentration: 70 nM
Estimate against measurement, compound 4: 2.1-fold (0.33 log units) above, and the stated range covers the measured number.
By their numbers in this assay, from the lowest: compounds 2, 4, 1 and 3 (each within the scatter of the next, the first and the last beyond it).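

In this assay, putting naphthalen-1-yl in place of 2,3-dihydro-1,4-benzodioxin-6-yl on the aromatic carbon between two ring nitrogen atoms gives no change at the digits printed from compound 2 to compound 4 (within the scatter). Among these compounds, this is the first direct reading of this position: the group that leaves holds 2 oxygen atoms and 2 hydrogen-bond acceptors, the group that enters holds only carbon, and in this pair those oxygen atoms are not needed to keep the number where it is. No measurement at hand says why the two groups score alike.

Going by these compounds, both groups have 10 heavy atoms, so it remains open whether something much smaller, such as a methyl group, or a group carrying an amine or a carboxylic acid, would be tolerated on this carbon. Also open, on these data alone, is whether the result holds when a group such as 4-pyridyl replaces the phenyl group two ring bonds away.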